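Anilide series: chloropropanamide to acetamide, cytotoxicity outlook

The source may hold more compounds than are shown below. What is called first, only, known or untested is meant among the compounds shown, and "the series" means these compounds.

In an ADME assay on MDCK cells (Canis lupus familiaris) for cytotoxicity, read by cytopathic effect, with a stated time of 48 h (on this read-out higher numbers stand for lower toxicity in this test and lower numbers for higher toxicity in this test), compound 3 `COc1ccc(C(=O)Nc2ccccc2)cc1NC(=O)C(C)Cl` gives 200 uM, the lowest of the two numbers available; the nearest is compound 1 `CCC(=O)Nc1cc(C(=O)NC2CCCCC2)ccc1OC`, which gives 510 uM, a gap beyond the scatter. Compound 2 `CCC(=O)Nc1cc(C(=O)NC2CCC2)ccc1OC` gives > 724 uM, which is an assay limit rather than a number, as noted in the limit of > 724 uM in this assay, at which 1 of the 3 values shown sits. Going by the values given here, the only measured step, an at least 1.4-fold higher number from compound 1 to compound 2 (0.15 log units; that floor lies within the scatter), concerns the substituent on the amide-type nitrogen, a different place from the change now considered. Compound 4 `COc1ccc(C(=O)Nc2ccccc2)cc1NC(C)=O` differs from compound 3 by methyl in place of 1-chloroethyl on a carbonyl carbon. Among the compounds with values here, no measured step covers this change, so no shift beyond the scatter is expected; the expected step in this assay is a 1.6-fold higher number from compound 3 to compound 4 (0.20 log units; within the scatter). Compound 4 is therefore estimated at 320 uM, between 150 uM and 700 uM.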

Compound 4, half-maximal toxic concentration: > 703 uM
Compound 4 gave a limit, no number; the forecaster's own chance of this, stated with the estimate: 25%; at least 2.1-fold (0.34 log units) between middle value and limit.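

Going by these compounds alone, this is the first measured change on the carbonyl carbon whose other neighbour is the amide-type nitrogen, and in this assay methyl in place of 1-chloroethyl gives an at least 3.5-fold higher number from compound 3 to compound 4 (0.54 log units; beyond the scatter) as the step. Within this pair, lower toxicity in this test goes with methyl. Compound 4 reads as a limit, not a number, so the full size of the step stays unknown: the limit of > 703 uM in this assay, at which 1 of the 4 values shown sits.

From the compounds shown here alone, whether the chlorine or the chain carries the step stays open. A chloromethyl group or a longer chloroalkyl chain on this carbonyl carbon would bear on that question.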